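Methoxy to Hydroxy on the Shared Core

This account rests on a few compounds, and the source may have more. Where it says the series, first, only, none or still open, it means among the compounds named here.

Compound 1, `COc1cccc(-c2nc3sccn3c2-c2ccnc(NCCNC(=O)Nc3cc(C(F)(F)F)cc(C(F)(F)F)c3)n2)c1`, gives 4300 nM in a functional assay on A375P cells (Homo sapiens) for antiproliferative activity, read by MTT assay, with a stated time of 48 h; a lower number here means a stronger inhibitor, a higher number a weaker inhibitor. Compound 2, `COc1cccc(-c2nc3sccn3c2-c2ccnc(NCCNC(=O)Nc3ccccc3)n2)c1`, reaches only the limit > 10000 nM in this assay, a boundary of the measurement rather than a number. Compound 3, `COc1cccc(-c2nc3sccn3c2-c2ccnc(NCCNC(=O)Nc3cccc(C(F)(F)F)c3)n2)c1`, gives 5300 nM in this assay.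

Among the two numbers, compound 1 stands lowest, but its nearest neighbour is close: a 1.2-fold higher number from compound 1 to compound 3 (0.09 log units; within the scatter). The other step, an at least 1.8-fold lower number from compound 2 to compound 3 (0.27 log units; that floor lies within the scatter), starts from the limit of > 10000 nM in this assay, at which 1 of the 3 values shown sits, and also stays within the scatter. Both measured steps concern a trifluoromethyl on the urea-bearing ring.

Compound 4, `O=C(NCCNc1nccc(-c2c(-c3cccc(O)c3)nc3sccn23)n1)Nc1cc(C(F)(F)F)cc(C(F)(F)F)c1`, differs from compound 1 elsewhere: hydrogen in place of methyl on an oxygen on an aromatic ring. For the measured compounds named here, no measured step touches this oxygen, so the two steps above offer no direct guide, and the change is expected to lead to no step beyond the scatter: a 1.0-fold higher number from compound 1 to compound 4 (0.02 log units; within the scatter). In this assay compound 4 is therefore estimated at 4500 nM, with a range from 1500 nM to 13000 nM.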

Compound 4, half-maximal inhibitory concentration: > 10000 nM
Compound 4: a limit, no number; the forecaster's own chance of this, stated with the estimate: 20%; middle value at least 2.2-fold (0.34 log units) away from the limit.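

For the compounds shown here, the oxygen on the 3-methoxyphenyl group, which no earlier step touched, turns out to matter in this assay: exchanging methoxy for hydroxy gives an at least 2.3-fold higher number from compound 1 to compound 4 (0.36 log units; beyond the scatter). The earlier compounds shown here differed only in trifluoromethyl on the urea-bearing ring and stayed within the scatter at each step, whereas here the loss of one methyl from this oxygen moves the result beyond it. The full size of the step stays unknown because compound 4 stands at a limit of the assay, as compound 2 does: the limit of > 10000 nM in this assay, at which 2 of the 4 values shown sit.

From the compounds shown here alone, it remains open whether the hydroxy itself or simply the loss of the methoxy drives this step, and an ethoxy or an amine in the same place would help separate the two. Going by these compounds, it is also open whether hydroxy acts the same way with the urea-bearing ring of compound 3 or compound 2.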